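This account rests on a few compounds, and the source may have more. Where it says the series, first, only, none or still open, it means among the compounds named here.

Working notes on a small series sharing one core, read in an ADME assay on MT4 cells (Homo sapiens) for cytotoxicity, read by MTT assay, with a stated time of 4 days; on this read-out higher numbers stand for lower toxicity in this test and lower numbers for higher toxicity in this test. Compound 1 `COC(=O)c1[nH]cc(C(=O)NCc2ccc(F)cc2)c(=O)c1O` gives 19000 nM, compound 2 `COCCNC(=O)c1[nH]cc(C(=O)NCc2ccc(F)cc2)c(=O)c1O` gives 16000 nM, and compound 3 `CNC(=O)c1[nH]cc(C(=O)NCc2ccc(F)cc2)c(=O)c1O` gives 8500 nM. Compound 3 is clearly separated only from compound 1, with a 2.2-fold lower number from compound 1 to compound 3 (0.35 log units; beyond the scatter). Against compound 2 the record shows a 1.9-fold lower number from compound 2 to compound 3 (0.27 log units; within the scatter), so those two cannot be told apart.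

Compound 4 `CN(C)C(=O)c1[nH]cc(C(=O)NCc2ccc(F)cc2)c(=O)c1O` differs from compound 3 by one change: methyl in place of hydrogen on an amide-type nitrogen. Read one bond further out, this turns methylcarbamoyl to dimethylcarbamoyl.

Within the data shown here, no measured step makes this exact change, so the evidence is indirect. The nearest steps replace groups on the same carbonyl carbon. Besides the two above, there is a 1.2-fold lower number from compound 1 to compound 2 (0.07 log units; within the scatter). Among the measured compounds shown here, only the step to compound 3 from compound 1 clears the scatter, and only modestly, so changes at this carbonyl have moved the number little so far. No step beyond the scatter is therefore expected in this assay, and no direction can be claimed. The expected step is a 1.2-fold higher number from compound 3 to compound 4 (0.07 log units; within the scatter). For compound 4 the estimated value is 10000 nM, with an expected range of 5000 nM to 20000 nM.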

Compound 4, half-maximal cytotoxic concentration: 5100 nM
Compound 4: the middle estimate sits 2.0-fold (0.29 log units) above what was measured; measured number inside the range.
By their numbers in this assay, from the lowest: compounds 4, 3, 2 and 1 (each within the scatter of the next, the first and the last beyond it).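

In this assay, among these compounds, the first direct reading of methyl in place of hydrogen on this amide-type nitrogen gives a 1.7-fold lower number from compound 3 to compound 4 (0.22 log units; within the scatter) and so stays within the scatter, which means this single change has no resolved effect on the number. Compound 4 does separate from the two compounds with other groups on the carbonyl carbon, with a 3.1-fold lower number from compound 2 to compound 4 (0.50 log units; beyond the scatter) as one modest step and a 3.7-fold lower number from compound 1 to compound 4 (0.57 log units; beyond the scatter) as another, so dimethylamino joins methylamino as a replacement for methoxy that clears the scatter, while (2-methoxyethyl)amino does not. No measurement shown here bears on the cause of these steps.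

Still open, going by these compounds, is whether the unsubstituted amide, with hydrogen in place of the remaining methyl on this nitrogen, would extend the same small step or break from it. Also open, on these data alone, is how an ethyl group or a longer chain on this nitrogen, or a carboxylic acid in place of the amide, would read in this assay against the modest spread seen so far.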